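A few compounds are considered here, and "the series" means these few. Any claim that something is new, unique, unknown or untested is made for them only; others in the source may bear on it.

Working notes on the series.

For the measured compounds named here, compound 2 `O=C1/C(=C/c2ccc(Cl)cc2)CCC/C1=C\c1ccccc1[N+](=O)[O-]` holds the lower of the two numbers so far: in a functional assay on L1210 cells (Mus musculus) for cytotoxicity, with a stated time of 48 h (on this read-out lower numbers stand for stronger inhibition and higher numbers for weaker inhibition), compound 2 gives 9380 nM. Compound 1 `COc1ccc(/C=C2\CCC/C(=C\c3ccccc3[N+](=O)[O-])C2=O)cc1` carries a methoxy where compound 2 carries a chloro; in this assay compound 1 gives 42400 nM, and the step is a 4.5-fold lower number from compound 1 to compound 2 (0.66 log units; beyond the scatter). Only these two values are known, so the spread of the series is that single step.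

Compound 3 `O=C1/C(=C/c2ccccc2)CCC/C1=C\c1ccccc1[N+](=O)[O-]` is the next case, still to be measured in this assay. Relative to compound 2 the change is hydrogen in place of chloro on an aromatic carbon; cut one bond further out it reads 4-chlorophenyl to phenyl. Going by the values given here, no measured pair shows this exact change. Among the compounds with values here, the one measured step, a 4.5-fold lower number from compound 1 to compound 2 (0.66 log units; beyond the scatter), shows that exchanging the group at this place moves the number by a modest amount, but it compares chloro with methoxy, not chloro with hydrogen, so it gives direction only loosely.

Compound 3 is therefore expected to give a number somewhat higher than compound 2, with the step estimated as a 1.7-fold higher number from compound 2 to compound 3 (0.23 log units; within the scatter), well short of the whole measured spread. For compound 3 the estimate in this assay is 16000 nM, with a range from 6000 nM to 45000 nM.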

Compound 3, half-maximal inhibitory concentration: 4840 nM
Compound 3: middle estimate off by 3.3-fold (0.52 log units), on the high side; the measured number lies below the stated range.
By their numbers in this assay, from the lowest: compounds 3 and 2 (each within the scatter of the next); then compound 1.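

Working from the three compounds, in this assay the chloro at this place on the aromatic carbon can give way to hydrogen with only a 1.9-fold lower number from compound 2 to compound 3 (0.29 log units; within the scatter) as the result, so the chloro is not needed to keep the number at the level of compound 2. Replacing the methoxy with hydrogen gives an 8.8-fold lower number from compound 1 to compound 3 (0.94 log units; beyond the scatter) and, read together with a 4.5-fold lower number from compound 1 to compound 2 (0.66 log units; beyond the scatter) as the earlier step, this sets methoxy apart from both chloro and hydrogen, the only separation beyond the scatter among the three groups at this place. Nothing on hand gives a reason for either difference.

From the compounds shown here alone, whether an amine, a carboxylic acid or a longer chain at this place would stay with compound 2 and compound 3 or move the number as the methoxy of compound 1 does remains open. The three compounds also differ only at this place, so they show nothing about how the number responds to changes elsewhere on the shared core.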